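Swapping halogens on the anilino ring of a shared core

The source may hold more compounds than are shown below. What is called first, only, known or untested is meant among the compounds shown, and "the series" means these compounds.

Compound 1 `CN1CCN(CCCOc2cccc3nc(Nc4ccc(Cl)c(F)c4)ccc23)CC1`: 1470 nM
Compound 2 `CC(C)c1ccc(Nc2ccc3c(OCCCN4CCN(C)CC4)cccc3n2)cc1`: 2050 nM
Compound 3 `CN1CCN(CCCOc2cccc3nc(Nc4ccc(F)c(F)c4)ccc23)CC1`: 660 nM

The three compounds share one core and differ only in the ring attached to the nitrogen on the aromatic ring. In a functional assay on K562 cells (Homo sapiens) for inhibition, read by sulforhodamine B assay, with a stated time of 48 h (on this read-out lower numbers stand for stronger inhibition of growth and higher numbers for weaker inhibition of growth), compound 3 gives the lowest number of the three: a 2.2-fold lower number from compound 1 to compound 3 (0.35 log units; beyond the scatter) and a 3.1-fold lower number from compound 2 to compound 3 (0.49 log units; beyond the scatter) both lie beyond the scatter, so compound 3 inhibits growth most strongly among them.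

Compound 4 `CN1CCN(CCCOc2cccc3nc(Nc4cccc(Cl)c4)ccc23)CC1` has not yet been measured. It differs from compound 3 in one place: 3-chlorophenyl in place of 3,4-difluorophenyl on a nitrogen on an aromatic ring. The step that bears most on this is a 2.2-fold lower number from compound 1 to compound 3 (0.35 log units; beyond the scatter), where replacing a chloro by a fluoro on the aromatic carbon gave a modestly lower number. Compound 4 goes the other way, bringing a chloro back in while losing both fluoro groups, so a modest rise in the number is expected rather than a fall. The step from compound 3 to compound 4 in this assay is estimated as a 1.8-fold higher number from compound 3 to compound 4 (0.26 log units; within the scatter). Compound 4 is therefore expected to give about 1200 nM, within a range from 500 nM to 3000 nM.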

Compound 4, concentration for 50% growth inhibition: 1790 nM
Estimate against measurement, compound 4: 1.5-fold (0.17 log units) below; the range from low to high includes it.
By their numbers in this assay, from the lowest: compound 3; then compounds 1, 4 and 2 (each within the scatter of the next).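

Changing 3,4-difluorophenyl to 3-chlorophenyl on the nitrogen gives a 2.7-fold higher number from compound 3 to compound 4 (0.43 log units; beyond the scatter) and so weakens growth inhibition, which shows that compound 3 also keeps its lead over a ring with a single chlorine and no fluoro. The new ring does not separate from the other two, with a 1.2-fold higher number from compound 1 to compound 4 (0.09 log units; within the scatter) and a 1.1-fold lower number from compound 2 to compound 4 (0.06 log units; within the scatter) both within the scatter, so compound 3 alone stands apart among the four while 3-chlorophenyl, 4-chloro-3-fluorophenyl and 4-isopropylphenyl sit level. Nothing measured here explains why the 3,4-difluorophenyl ring stands apart.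

A phenyl ring with one fluoro would help tell whether the lower number needs both fluoro groups or only one. A nitrile or a methoxy group on that ring would show whether a non-halogen group can match 3,4-difluorophenyl.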